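The source may hold more compounds than are shown below. What is called first, only, known or untested is meant among the compounds shown, and "the series" means these compounds.

Compound 2 `CN(C)CCn1cnnc1-c1cc(Oc2ccc(NC(=O)N/N=C/c3ccc(Cl)cc3)cc2F)ccn1` gives 570 nM in a functional assay on MKN-45 cells (Homo sapiens) for cytotoxicity, read by MTT assay, with a stated time of 72 h (on this read-out higher numbers stand for weaker inhibition and lower numbers for stronger inhibition), the lowest of the two numbers recorded so far. Compound 1 `CN(C)CCn1cnnc1-c1cc(Oc2ccc(NC(=O)N/N=C/c3ccc(Cl)cc3Cl)cc2F)ccn1` gives 750 nM in this assay, and the step of a 1.3-fold lower number from compound 1 to compound 2 (0.12 log units; within the scatter) lies within the scatter. Compound 3 `COc1ccc(/C=N/NC(=O)Nc2ccc(Oc3ccnc(-c4nncn4CCN(C)C)c3)c(F)c2)cc1O` differs from compound 2 by 3-hydroxy-4-methoxyphenyl in place of 4-chlorophenyl on a carbon with a double bond to nitrogen. For the measured compounds named here, the only measured step on this aryl group, the loss of one chloro, moved nothing beyond the scatter, and no measured step bears directly on a hydroxy-methoxy substitution, so in this assay no step beyond the scatter is expected. Compound 3 is estimated at 700 nM in this assay, range 250 nM to 2000 nM. The expected step is a 1.2-fold higher number from compound 2 to compound 3 (0.09 log units; within the scatter).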

Compound 3, half-maximal inhibitory concentration: 2510 nM
For compound 3 the middle estimate is 3.6-fold (0.55 log units) below the measured one; the whole stated range lies below it.
By their numbers in this assay, from the lowest: compounds 2 and 1 (each within the scatter of the next); then compound 3.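

In this assay, the aryl group on the carbon with a double bond to nitrogen now shows a change beyond the scatter: there is a 4.4-fold higher number from compound 2 to compound 3 (0.64 log units; beyond the scatter) and also a 3.3-fold higher number from compound 1 to compound 3 (0.52 log units; beyond the scatter). Removing one chloro had not separated compound 1 from compound 2, whereas replacing the chlorinated aryl groups with 3-hydroxy-4-methoxyphenyl does separate compound 3 from both. Nothing available accounts for this shift.

As far as these compounds go, whether the hydroxy or the methoxy drives the shift remains open, since the two groups enter together. Also open, from the compounds shown here alone, is how a nitrile or a carboxylic acid on this aryl group would read.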